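Removing the aromatic methyl from compound 2

The compounds below may be only part of what the source reports. "The series", "measured", "known", "first", "only" and "open" are said of these compounds alone.

Values measured in an ADME assay on Vero cells (Chlorocebus sabaeus) for cytotoxicity, read by MTT assay, with a stated time of 72 h (a higher number here means that more compound is tolerated, a lower number that less compound is tolerated), are as follows
compound 1 `COc1c(N2C[C@H]3CCCN(Cc4cn(CCCN5C(=O)C(=O)c6ccccc65)nn4)[C@H]3C2)c(F)cc2c(=O)c(C(=O)O)cn(C3CC3)c12` gives 16 ug/mL
compound 2 `COc1c(N2C[C@H]3CCCN(Cc4cn(CCCN5C(=O)/C(=N/O)c6cc(C)ccc65)nn4)[C@H]3C2)c(F)cc2c(=O)c(C(=O)O)cn(C3CC3)c12` gives 8 ug/mL
compound 3 `CCO/N=C1/C(=O)N(CCCn2cc(CN3CCC[C@@H]4CN(c5c(F)cc6c(=O)c(C(=O)O)cn(C7CC7)c6c5OC)C[C@@H]43)nn2)c2ccc(C)cc21` gives 4 ug/mL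

Compound 2 holds the second highest of the three numbers, and its gaps to compound 1 and compound 3 both lie within the scatter. The next compound, compound 4 `COc1c(N2C[C@H]3CCCN(Cc4cn(CCCN5C(=O)/C(=N/O)c6ccccc65)nn4)[C@H]3C2)c(F)cc2c(=O)c(C(=O)O)cn(C3CC3)c12`, differs from compound 2 by hydrogen in place of methyl on an aromatic carbon and so carries hydrogen in place of methyl on an aromatic carbon. Among the compounds with values here, no measured step isolates this change. Within the data shown here, the one measured step is a 2.0-fold lower number from compound 2 to compound 3 (0.30 log units; within the scatter) with ethyl in place of hydrogen on an oxygen, so it concerns a different place and gives only a rough sense of how far one small substitution moves the number here. Compound 1 also has no methyl and gives 16 ug/mL in this assay but it differs from compound 4 elsewhere too, so it is a weak guide. The expected step is a 1.3-fold higher number from compound 2 to compound 4 (0.10 log units; within the scatter) in this assay and no change beyond the scatter is expected in either direction. Compound 4 is estimated at 10 ug/mL (expected range 4 ug/mL to 20 ug/mL).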

Compound 4, half-maximal cytotoxic concentration: 8 ug/mL
Compound 4: the middle estimate sits 1.3-fold (0.10 log units) above what was measured; the measured number falls inside the stated range.
By their numbers in this assay, from the lowest: compounds 3, 2, 4 and 1 (each within the scatter of the next, the first and the last beyond it).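

In this assay, the methyl on an aromatic carbon of the six-membered aromatic ring of carbon only now has a step of its own: no change at the digits printed from compound 2 to compound 4 (within the scatter), so hydrogen and methyl cannot be told apart at this position in this assay. Compound 4 also links the methyl-free pair, with a 2.0-fold lower number from compound 1 to compound 4 (0.30 log units; within the scatter) for the exchange of the group on the saturated chain carbon, three bonds along the chain from an aromatic nitrogen, and this step too stays inside the usual scatter of repeated measurements. The series offers no measurement that explains either reading, so this note gives no cause for the result.

On these data alone, only hydrogen and methyl have been compared at this aromatic carbon, so the response to a chlorine, a methoxy group, an amine or a carboxylic acid there remains open, as does any trend across larger groups. Also open, as far as these compounds go, is whether ethyl in place of hydrogen on an oxygen would read the same in this assay on the methyl-free compound 4 as it does on the methyl-bearing compound 2.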